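Acetyl for methylsulfonyl on the amine nitrogen of compound 3

The source may report more compounds than this note shows. Statements on the series, on what has been measured and on what is new or still open speak of the compounds shown alone.

Among the compounds with values here, compound 3 `CCCC[S+]([O-])c1sc2nc(-c3nccs3)cc(-c3ccc(CNS(C)(=O)=O)cc3)c2c1N` gives 4.6 nM in an assay for inhibition of 15-hydroxyprostaglandin dehydrogenase [NAD(+)] (Homo sapiens), read by fluorescence, with a stated time of 15 min, in the presence of a further agent that is not named here (a lower number here means a stronger inhibitor, a higher number a weaker inhibitor), the lowest of the three numbers measured so far. Compound 2 `CCCC[S+]([O-])c1sc2nc(-c3nccs3)cc(-c3ccc(C(=O)N(C)C)cc3)c2c1N` gives 5.9 nM, within the scatter of compound 3. Compound 1 `CCCC[S+]([O-])c1sc2nc(-c3nccs3)cc(-c3ccc(C(=O)OC)cc3)c2c1N` gives 15.1 nM; the step of a 3.3-fold lower number from compound 1 to compound 3 (0.52 log units; beyond the scatter) is modest but beyond the scatter, as is a 2.6-fold lower number from compound 1 to compound 2 (0.41 log units; beyond the scatter). The step of a 1.3-fold lower number from compound 2 to compound 3 (0.11 log units; within the scatter) stays within the scatter.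

Compound 4 `CCCC[S+]([O-])c1sc2nc(-c3nccs3)cc(-c3ccc(CNC(C)=O)cc3)c2c1N` differs from compound 3 in one place: acetyl in place of methylsulfonyl on an amine nitrogen. Within the data shown here, no measured pair changes the group on the amine nitrogen itself. Among the measured compounds shown here, the only step that touches this side chain, a 1.3-fold lower number from compound 2 to compound 3 (0.11 log units; within the scatter), exchanges the whole group and remains within the scatter, while the two modest steps from compound 1 concern the methoxycarbonyl group rather than the sulfonamide. A step of the same kind is therefore not available. The expectation in this assay is a step no larger than the scatter, a 1.3-fold higher number from compound 3 to compound 4 (0.12 log units; within the scatter), in either direction. Compound 4 is estimated at 6 nM, with a range of 3 nM to 13 nM.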

Compound 4, half-maximal inhibitory concentration: 2.5 nM
Compound 4: the middle estimate sits 2.4-fold (0.38 log units) above what was measured; measured number below the stated range.
By their numbers in this assay, from the lowest: compounds 4, 3 and 2 (each within the scatter of the next, the first and the last beyond it); then compound 1.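

In this assay, within the data shown here, the one exchange made on the amine nitrogen itself, a 1.8-fold lower number from compound 3 to compound 4 (0.26 log units; within the scatter), stays within the scatter, so acetyl and methylsulfonyl are not told apart on this nitrogen. On the aromatic carbon, acetamidomethyl is separated beyond the scatter from both carbonyl groups, with a 2.4-fold lower number from compound 2 to compound 4 (0.37 log units; beyond the scatter) and a 6.0-fold lower number from compound 1 to compound 4 (0.78 log units; beyond the scatter), whereas (methanesulfonamido)methyl stays within the scatter of dimethylcarbamoyl. No measurement available here accounts for these steps.

The compounds shown leave open how a free amine or a carboxylic acid would read on the aromatic carbon, and whether a longer acyl chain such as propanoyl would hold up on the amine nitrogen. Also open, on these data alone, is the result of a methyl group in place of the amide hydrogen of compound 4.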